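Notes on the step from compound 1 to compound 4

The source may hold more compounds than are shown below. What is called first, only, known or untested is meant among the compounds shown, and "the series" means these compounds.

In a functional assay on HeLa cells (Homo sapiens) for antiproliferative activity, read by resazurin assay (on this read-out higher numbers stand for weaker inhibition and lower numbers for stronger inhibition), compound 1 `CCSC(=S)SCC(=O)c1ccc(C)cc1` gives 3980 nM and compound 3 `CSC(=S)SCC(=O)c1ccc(C)cc1` gives 3160 nM with a 1.3-fold lower number from compound 1 to compound 3 (0.10 log units; within the scatter) between them, so these two sit together. Compound 2 `Cc1ccc(C(=O)CSC(=S)SC(C)C)cc1` gives 25100 nM and a 6.3-fold higher number from compound 1 to compound 2 (0.80 log units; beyond the scatter) places compound 1 clearly apart from it.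

Compound 4 `CCSC(=S)SCC(=O)c1ccc(OC(F)F)cc1` differs from compound 1 by difluoromethoxy in place of methyl on an aromatic carbon and the change is difluoromethoxy in place of methyl on an aromatic carbon. Every measured step alters only the chain on sulfur, so none bears directly on this position. The steps of a 6.3-fold higher number from compound 1 to compound 2 (0.80 log units; beyond the scatter) and a 7.9-fold lower number from compound 2 to compound 3 (0.90 log units; beyond the scatter) give no more than the scale of change seen so far in the series. On these data alone, with no measured change on the aromatic ring to go on, no step beyond the scatter is expected in this assay and a modest move in either direction stays open.

The estimated step is a 1.0-fold higher number from compound 1 to compound 4 (0.00 log units; within the scatter) on this reasoning. For compound 4 the expected value is 4000 nM with an estimated range of 1500 nM to 11000 nM on this read-out.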

Compound 4, half-maximal inhibitory concentration: 3980 nM
For compound 4 the middle estimate is 1.0-fold (0.00 log units) above the measured one; low and high end bracket the measured number.
By their numbers in this assay, from the lowest: compounds 3, 1 and 4 (each within the scatter of the next); then compound 2.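

Among these compounds, this is the first measured change on the aromatic ring: in this assay the exchange of methyl for difluoromethoxy gives no change at the digits printed from compound 1 to compound 4 (within the scatter) and stays within the scatter, so this position accepts a group of 4 heavy atoms with 1 hydrogen-bond acceptor without a readable change. The chain on sulfur, by contrast, has produced a step beyond the scatter, as in a 6.3-fold higher number from compound 1 to compound 2 (0.80 log units; beyond the scatter) and yet not in a 1.3-fold lower number from compound 1 to compound 3 (0.10 log units; within the scatter). No supporting measurement bears on this result.

A single exchange leaves open whether an amine, a carboxylic acid or a longer chain at this position would also leave the number unchanged. On these data alone, it is also open whether difluoromethoxy would read the same alongside the isopropyl on sulfur of compound 2.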